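The source may hold more compounds than are shown below. What is called first, only, known or untested is meant among the compounds shown, and "the series" means these compounds.

Measured compounds:
Compound 1 `COc1cc2c(Oc3ccc(NC(=O)c4cn(-c5c(Cl)cccc5Cl)nn4)cc3F)ccnc2cc1OCCCN1CCCCC1`: 280 nM
Compound 2 `COc1cc2c(Oc3ccc(NC(=O)c4cn(-c5ccc(F)c(F)c5)nn4)cc3F)ccnc2cc1OCCCN1CCCCC1`: 250 nM
Compound 3 `COc1cc2c(Oc3ccc(NC(=O)c4cn(-c5c(Cl)cccc5Cl)nn4)cc3F)ccnc2cc1OCCCN1CCC(C)CC1`: 270 nM

All three were tested in a functional assay on NCI-H460 cells (Homo sapiens) for cytotoxicity, read by MTT assay, with a stated time of 72 h; on this read-out higher numbers stand for weaker inhibition and lower numbers for stronger inhibition. The three values sit close together. The step from compound 1 to compound 2 is a 1.1-fold lower number from compound 1 to compound 2 (0.05 log units; within the scatter), which is 3,4-difluorophenyl in place of 2,6-dichlorophenyl on an aromatic nitrogen. The step from compound 1 to compound 3 is a 1.0-fold lower number from compound 1 to compound 3 (0.02 log units; within the scatter), which is methyl in place of hydrogen on a saturated ring carbon. Going by the values given here, for compounds 2 and 3 no step is worked out here; their two values show only that they lie near each other.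

Compound 4 `COc1cc2c(Oc3ccc(NC(=O)c4cn(-c5ccc(F)c(F)c5)nn4)cc3F)ccnc2cc1OCCCN1CCC(C)CC1` has not yet been measured in this assay. It differs from compound 3 by 3,4-difluorophenyl in place of 2,6-dichlorophenyl on an aromatic nitrogen. Among the compounds with values here, this is the same change as the one from compound 1 to compound 2: the groups that leave and enter are the same and the place is described in the same words, so the two changes are the same. The cores of compound 3 and compound 1, on which the change is made, differ by methyl in place of hydrogen on a saturated ring carbon.

Because the earlier instance of this change gave a 1.1-fold lower number from compound 1 to compound 2 (0.05 log units; within the scatter), the step from compound 3 to compound 4 in this assay is expected to be of like size, a 1.1-fold lower number from compound 3 to compound 4 (0.05 log units; within the scatter), resting on that single precedent and on the value of compound 3, 270 nM. Compound 4 is therefore estimated at 240 nM in this assay. The estimate for compound 4 is expected to fall between 120 nM and 480 nM.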

Compound 4, half-maximal inhibitory concentration: 260 nM
Compound 4: the middle estimate sits 1.1-fold (0.03 log units) below what was measured; the range from low to high includes it.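

In this assay, 3,4-difluorophenyl in place of 2,6-dichlorophenyl on an aromatic nitrogen gives a 1.0-fold lower number from compound 3 to compound 4 (0.02 log units; within the scatter), and this step agrees with the earlier instance on the core without the methyl: the same change on two cores in this assay, a 1.1-fold lower number (0.05 log units; within the scatter) from compound 1 to compound 2 and a 1.0-fold lower number (0.02 log units; within the scatter) from compound 3 to compound 4, 1.1-fold (0.03 log units) apart, within the scatter of two such steps

Methyl in place of hydrogen on a saturated ring carbon gives a 1.0-fold higher number from compound 2 to compound 4 (0.02 log units; within the scatter), and this step likewise agrees with its earlier instance, now on the core carrying 3,4-difluorophenyl: the same change on two cores in this assay, a 1.0-fold lower number (0.02 log units; within the scatter) from compound 1 to compound 3 and a 1.0-fold higher number (0.02 log units; within the scatter) from compound 2 to compound 4, 1.1-fold (0.03 log units) apart, within the scatter of two such steps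

Both changes therefore read the same on the two cores compared, but all four steps lie within the scatter, so this is agreement between steps too small to separate from repeat measurement, and it does not show that a step of real size would carry from one core to another or that these changes would behave alike on further cores.

The compounds shown leave open what an unsubstituted phenyl or a benzyl group on that aromatic nitrogen would give on these cores. They also leave open what a morpholine or an open-chain dimethylamino group would give in place of the saturated ring that carries the methyl in compound 3 and compound 4.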